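Isobutyl to tert-butyl: one rearranged chain on the core

The compounds below may be only part of what the source reports. "The series", "measured", "known", "first", "only" and "open" are said of these compounds alone.

In a physicochemical assay for solubility, in phosphate buffer, with a stated time of 18 h (on this read-out lower numbers stand for lower solubility and higher numbers for higher solubility), three compounds with the same core have been measured:
compound 1 `N#Cc1c(N)nc2nc(C3CC3)ncc2c1N` gives 23000 nM
compound 2 `N#Cc1c(N)nc2nc(C3CCC3)ncc2c1N` gives 217000 nM
compound 3 `CC(C)Cc1ncc2c(N)c(C#N)c(N)nc2n1` gives 268000 nM

Compound 3 has the highest of the three numbers, yet compound 2 lies within the scatter of it, so those two cannot be ordered; only compound 1 is clearly lower, as a 12-fold higher number from compound 1 to compound 3 (1.07 log units; beyond the scatter) shows. Compound 4 `CC(C)(C)c1ncc2c(N)c(C#N)c(N)nc2n1` has not yet been measured in this assay. The change is tert-butyl in place of isobutyl on an aromatic carbon. Among the measured compounds shown here, no measured step swaps one open four-carbon group for another, so the nearest guides are a 1.2-fold higher number from compound 2 to compound 3 (0.09 log units; within the scatter), a small change between two groups of equal size, and a 9.4-fold higher number from compound 1 to compound 2 (0.97 log units; beyond the scatter), a larger one where a ring grows by one carbon. Compound 4 is expected to stay close to the upper pair, with no step beyond the scatter: the expected step is a 1.1-fold lower number from compound 3 to compound 4 (0.03 log units; within the scatter). For compound 4 the estimate in this assay is 250000 nM, within 100000 nM to 600000 nM.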

Compound 4, solubility: 37200 nM
For compound 4 the middle estimate is 6.7-fold (0.83 log units) above the measured one, outside the stated range (below it).
By their numbers in this assay, from the lowest: compounds 1 and 4 (each within the scatter of the next); then compounds 2 and 3 (each within the scatter of the next).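

In this assay the change from isobutyl to tert-butyl gives a 7.2-fold lower number from compound 3 to compound 4 (0.86 log units; beyond the scatter) even though the two groups hold the same atoms, so at this position the way the carbons are joined counts, not only how many there are. Tert-butyl also parts from cyclobutyl, with a 5.8-fold lower number from compound 2 to compound 4 (0.77 log units; beyond the scatter) and stays level with cyclopropyl, with a 1.6-fold higher number from compound 1 to compound 4 (0.21 log units; within the scatter) which leaves compounds 1 and 4 as one pair and compounds 2 and 3 as the other. No measurement here explains why these groups divide this way.

Going by these compounds, it remains open where other groups at this position would fall, such as a longer chain, an amine or a carboxylic acid. On these data alone, it is also open whether swapping isobutyl for tert-butyl would give a step of this size on a different core.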